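Chalcone-pyrazole series: aryl swap on the carbonyl

The source may hold more compounds than are shown below. What is called first, only, known or untested is meant among the compounds shown, and "the series" means these compounds.

Measured so far:
compound 1, `COc1cc(-c2cc(/C=C/C(=O)c3ccc(Cl)c(Cl)c3)[nH]n2)cc(OC)c1OC`: 1660 nM
compound 2, `COc1ccc(-c2cc(/C=C/C(=O)c3ccc(N)cc3)[nH]n2)cc1OC`: 4250 nM

Compound 1 gives the lowest number of the two in a functional assay on T47D cells (Homo sapiens) for inhibition, read by sulforhodamine B assay, with a stated time of 48 h; a lower number here means a stronger inhibitor of growth, a higher number a weaker inhibitor of growth. Compound 2 stands higher, and that gap lies beyond the usual scatter, so compound 1 is the stronger growth inhibitor of the pair. Compound 2 also differs from compound 1 in more than one place, so no single step can be read from the two values.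

Compound 3, `COc1ccc(C(=O)/C=C/c2cc(-c3cc(OC)c(OC)c(OC)c3)n[nH]2)cc1OC`, has not yet been measured in this assay. It departs from compound 1 in one place: 3,4-dimethoxyphenyl in place of 3,4-dichlorophenyl on a carbonyl carbon. Nothing in the measured pair shows this exact change on a carbonyl carbon, so the expectation rests on the general level of the series rather than on a shown step.

The expected outcome is a modest step from compound 1 to compound 3 towards a higher number, near the edge of the scatter: a 1.6-fold higher number from compound 1 to compound 3 (0.19 log units; within the scatter). The estimate for compound 3 in this assay is 2600 nM, with a range from 900 nM to 7500 nM.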

Compound 3, concentration for 50% growth inhibition: 1630 nM
For compound 3 the middle estimate is 1.6-fold (0.20 log units) above the measured one; measured number inside the range.
By their numbers in this assay, from the lowest: compounds 3 and 1 (each within the scatter of the next); then compound 2.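

For the compounds shown here, on the carbonyl carbon, 3,4-dimethoxyphenyl in place of 3,4-dichlorophenyl gives a 1.0-fold lower number from compound 1 to compound 3 (0.01 log units; within the scatter) in this assay, and this is the first single-place comparison available. The two groups cannot be told apart in this read-out, even though 3,4-dimethoxyphenyl counts hydrogen-bond acceptors and 3,4-dichlorophenyl counts none, so at this position the exchange of the chlorine substituents for methoxy substituents leaves the growth-inhibition number unmoved within the scatter. No supporting measurement bears on why the two groups read alike.

The steps involving compound 2 cannot be read, as it differs from compound 1 and from compound 3 in more than one place, so the contribution of its own carbonyl-side aryl group stays unresolved. Whether this flat response holds more widely is open: an unsubstituted phenyl, a carboxylic acid or a longer alkoxy chain on the aryl group at the carbonyl carbon could show whether the position tolerates change generally or whether these two groups merely happen to coincide.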